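The source may hold more compounds than are shown below. What is called first, only, known or untested is meant among the compounds shown, and "the series" means these compounds.

Measured compounds in the series:

compound 1, `ClCc1ccccc1Cn1cnc2c(Cl)nc(Cl)nc21` — 3630 nM
compound 2, `ClCc1cccc(Cn2cnc3c(Cl)ncnc32)c1` — 5120 nM
compound 3, `ClCc1cccc(Cn2cnc3nc(Cl)nc(Cl)c32)c1` — 3630 nM

All three values come from a functional assay on HOP-62 cells (Homo sapiens) for cytotoxicity, read by sulforhodamine B assay, with a stated time of 48 h; on this read-out lower numbers stand for stronger inhibition of growth and higher numbers for weaker inhibition of growth. Compound 1 stands level with compound 3 at the digits read, and the two together give the lowest numbers of the three. Compound 2 gives the highest number, but its gap to compound 1 is within the scatter of repeated measurements, so no ordering among the three can be claimed on this read-out; the set is flat.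

The next compound, compound 4, is `Nc1nc(Cl)c2ncn(Cc3ccccc3CCl)c2n1`. Relative to compound 1 the difference is amino in place of chloro on an aromatic carbon. Going by the values given here, no pair of measured compounds carries this change, so there is no measured step to lean on. The three measured numbers sit close together, which gives no sign that changes on the shared core move this assay far. The step from compound 1 to compound 4 is therefore expected to be modest, and the direction is uncertain; a small move toward weaker inhibition is the working guess, as a 1.7-fold higher number from compound 1 to compound 4 (0.22 log units; within the scatter). Compound 4 is expected to give about 6000 nM, in the range 2500 nM to 15000 nM.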

Compound 4, concentration for total growth inhibition: 61700 nM
Compound 4: middle estimate off by 10-fold (1.01 log units), on the low side; measured number outside the range, above it.
By their numbers in this assay, from the lowest: compounds 1, 3 and 2 (each within the scatter of the next); then compound 4.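

In this assay, going by these compounds alone, amino in place of chloro on an aromatic carbon, between two ring nitrogen atoms, gives a 17-fold higher number from compound 1 to compound 4 (1.23 log units; beyond the scatter) as a large step, the first one in a series that had so far been flat across compound 1, compound 2 and compound 3. The flat set therefore did not speak for this position: the number depends strongly on which group sits here, at least for this one exchange. The exchange removes one chlorine and brings in a group counted with one hydrogen-bond donor and one hydrogen-bond acceptor, but nothing measured here ties the step to either feature, and no measurement on these compounds offers an explanation for it.

With only one replacement shown at this position, it remains open whether the step follows from the arrival of amino or from the departure of chloro; methoxy or methylamino in the same place would help to separate the two. Also open, on these data alone, is whether the same exchange at the remaining chloro group would move the number to a similar extent.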